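A few compounds are considered here, and "the series" means these few. Any claim that something is new, unique, unknown or untested is made for them only; others in the source may bear on it.

Of the compounds shown here, three sharing one core have been measured so far in a functional assay on KB cells (Homo sapiens) for inhibition (a lower number here means a stronger inhibitor, a higher number a weaker inhibitor), with only one exact result. Within the data shown here, compound 1 (`COc1ccc(Cn2c(N)nc3cc(Cl)c(Cl)cc32)cc1`) gives 45000 nM as the only true number among them. Compound 2 (`Clc1cc2nc(Cl)n(Cc3ccccc3)c2cc1Cl`) is reported as > 100000 nM and that is a limit of the assay, not a number. Compound 3 (`Clc1ccc(Cn2c(Cl)nc3cc(Cl)c(Cl)cc32)cc1`) is reported as > 100000 nM and that too is a limit. So compound 3 stands at the limit of > 100000 nM in this assay, at which 2 of the 3 values shown sit, and offers no exact value as a starting point.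

Compound 4 (`COc1ccc(Cn2c(Cl)nc3cc(Cl)c(Cl)cc32)cc1`) differs from compound 3 in one place, with methoxy in place of chloro on an aromatic carbon, para to a large group (methoxy in place of chloro on an aromatic carbon). Among the measured compounds shown here, the only measured step bearing on this change is a step that the two limits leave unreadable from compound 2 to compound 3 and it gives no size to carry over. No step beyond the scatter can therefore be argued for in this assay and no direction is expected either. The expected change is a number no higher from compound 3 to compound 4 (the limit leaves the size open) on that reasoning. Compound 4 is estimated at 100000 nM with a range from 50000 nM to 200000 nM and may well turn out to be only a limit.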

Compound 4, half-maximal inhibitory concentration: > 100000 nM
Compound 4 gave a limit, no number; the forecaster's own chance of this, stated with the estimate: 75%; the middle value lies on the limit itself.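

In this assay compound 4 gives > 100000 nM, which is a limit and not a number, so methoxy on this aromatic carbon, para to a large group, does not bring a compound carrying chloro on the core to a measurable value, and it ends at the same reading as the others: the limit of > 100000 nM in this assay, at which 3 of the 4 values shown sit. The steps linking compound 4 to compound 2 and compound 3 have a limit at both ends and cannot be read. The one readable step is an at least 2.2-fold higher number from compound 1 to compound 4 (0.34 log units; beyond the scatter), with chloro in place of amino while methoxy stays the same in both, so the place of the amino group, not the place of the methoxy, is where a change of this series has now shown a size.

Going by these compounds, it remains open whether the group on this aromatic carbon matters at all once the amino group is kept, which an amino compound with chloro or hydrogen in place of methoxy could show. On these data alone, it is also open whether dimethylamino or hydroxyl in the place of amino would give a lower number than compound 1 at 45000 nM.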